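Cyclobutyl for Methoxymethyl: What Compound 4 Should Show

The compounds below may be only part of what the source reports. "The series", "measured", "known", "first", "only" and "open" are said of these compounds alone.

Measured so far:
compound 1 `CCCCCn1c(Cc2cc(OC)c(OC)c(OC)c2)nc2c(N)nc(F)nc21`: 36300 nM
compound 2 `COc1cc(Cc2nc3c(N)ncnc3n2CC2CCC2)cc(OC)c1OC`: 45700 nM
compound 3 `COCCn1c(Cc2cc(OC)c(OC)c(OC)c2)nc2c(N)nc(F)nc21`: 64600 nM

In a functional assay on MCF7 cells (Homo sapiens) for antiproliferative activity (a higher number here means a weaker inhibitor, a lower number a stronger inhibitor), compound 3 gives 64600 nM, the highest of the three numbers, although its gaps to compound 2 and to compound 1 both lie within the scatter. Compound 4 `COc1cc(Cc2nc3c(N)nc(F)nc3n2CC2CCC2)cc(OC)c1OC` has not yet been measured; it differs from compound 3 by cyclobutyl in place of methoxymethyl on a saturated chain carbon bound to an aromatic nitrogen. Going by the values given here, no measured step makes this same exchange. Among the compounds with values here, the one step on the same chain, a 1.8-fold higher number from compound 1 to compound 3 (0.25 log units; within the scatter), bears on it only loosely. Compound 2, which also carries a cyclobutyl on a saturated chain carbon bound to an aromatic nitrogen, gives 45700 nM in this assay, close to compound 3. The step of a 1.4-fold lower number from compound 3 to compound 4 (0.16 log units; within the scatter) is therefore expected to stay within the scatter. Compound 4 is estimated at 45000 nM, with a range from 20000 nM to 100000 nM.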

Compound 4, half-maximal inhibitory concentration: 40700 nM
Compound 4: middle estimate off by 1.1-fold (0.04 log units), on the high side; the range from low to high includes it.
By their numbers in this assay, from the lowest: compounds 1, 4, 2 and 3 (each within the scatter of the next).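

In this assay the exchange now has a step of its own, with a 1.6-fold lower number from compound 3 to compound 4 (0.20 log units; within the scatter) staying within the scatter. The two other changes read the same way: fluoro in place of hydrogen on an aromatic carbon gives a 1.1-fold lower number from compound 2 to compound 4 (0.05 log units; within the scatter) and stays within the scatter, and cyclobutyl in place of butyl gives a 1.1-fold higher number from compound 1 to compound 4 (0.05 log units; within the scatter) and does likewise. Nothing measured here offers an explanation for these steps.

Still open, as far as these compounds go, is whether an amine or a carboxylic acid at this place on the chain would give a step beyond the scatter.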